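Amide variation on the pyridine carboxamide arm

This account rests on a few compounds, and the source may have more. Where it says the series, first, only, none or still open, it means among the compounds named here.

Measured so far:
compound 1 `Cn1ccc2ccc(-c3cc(Nc4ccccc4S(=O)(=O)NCC4CCOCC4)cc4nccnc34)cc21` — 26 nM
compound 2 `CN(C)C(=O)c1ccncc1Nc1cc(-c2ccc3ccn(C)c3c2)c2nccnc2c1` — 499 nM

In an assay for inhibition of 6-phosphofructo-2-kinase/fructose-2,6-bisphosphatase 3 (Homo sapiens), read by ADP-Glo, with a stated time of 2 h (on this read-out lower numbers stand for stronger inhibition and higher numbers for weaker inhibition), compound 2 gives 499 nM, the higher of the two numbers recorded; compound 1 gives 26 nM, a gap that lies beyond the scatter. For the measured compounds named here, only these two sit on the series so far, and they differ in several places at once, so no single-change step is available.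

Compound 3 `Cn1cc(CNC(=O)c2ccncc2Nc2cc(-c3ccc4ccn(C)c4c3)c3nccnc3c2)cn1` keeps the core of compound 2 and alters the amide: ((1-methyl-1H-pyrazol-4-yl)methyl)amino in place of dimethylamino on a carbonyl carbon. The entering group brings a hydrogen-bond donor and a ring that the leaving group lacks; compound 1, the lower number, likewise carries a secondary amide-type hydrogen bearing a ring-containing chain, though on a different linker.

Going by the values given here, with no measured step of this kind, the expectation for compound 3 is a modest move toward stronger inhibition, a 2.0-fold lower number from compound 2 to compound 3 (0.30 log units; within the scatter), with wide uncertainty. Compound 3 is estimated at 250 nM, within 60 nM to 1000 nM.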

Compound 3, half-maximal inhibitory concentration: 159 nM
Estimate against measurement, compound 3: 1.6-fold (0.20 log units) above, and the stated range covers the measured number.
By their numbers in this assay, from the lowest: compound 1; then compound 3; then compound 2.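

For the compounds shown here, on the carbonyl carbon, the larger ((1-methyl-1H-pyrazol-4-yl)methyl)amino group is accepted in place of dimethylamino: this assay gives a 3.1-fold lower number from compound 2 to compound 3 (0.50 log units; beyond the scatter) as the first single-place reading. The change adds a ring and the amide hydrogen together, so this one step shows that inhibition at this position responds to the amide substituent, but it cannot divide the shift between those features. Nothing available assigns a cause to the step.

From the compounds shown here alone, it remains open whether the amide hydrogen alone accounts for the shift, which a methylamino group would test, or whether the ring is required, which a pyrrolidine amide would test. Going by these compounds, the effect of a longer chain between the amide nitrogen and the pyrazole, or of a phenyl ring in its place, also remains open.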